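The source may hold more compounds than are shown below. What is called first, only, known or untested is meant among the compounds shown, and "the series" means these compounds.

Compound 1 `O=C(O)c1cn(C2CC2)c2c(Cl)c(N3CCN(Cn4nc(-c5ccccc5O)n(Cc5ccc(F)cc5)c4=S)CC3)c(F)cc2c1=O`: 50500 nM
Compound 2 `O=C(O)c1cn(C2CC2)c2c(Cl)c(N3CCN(Cn4nc(-c5ccccc5O)n(-c5cc(Cl)cc(Cl)c5)c4=S)CC3)c(F)cc2c1=O`: 50500 nM

In a toxicity assay on HEK293 cells (Homo sapiens) for cytotoxicity, read by MTT assay, with a stated time of 72 h (a lower number here means that less compound is needed, a higher number that more compound is needed for the effect), compound 2 gives 50500 nM, level with compound 1. Compound 3 `COc1ccc(Cn2c(-c3ccccc3O)nn(CN3CCN(c4c(F)cc5c(=O)c(C(=O)O)cn(C6CC6)c5c4Cl)CC3)c2=S)cc1` has 4-methoxybenzyl in place of 3,5-dichlorophenyl on an aromatic nitrogen. Within the data shown here, only one measured step bears on this swap, no change at the digits printed from compound 1 to compound 2 (within the scatter), which exchanged 4-fluorobenzyl for 3,5-dichlorophenyl on an aromatic nitrogen and stayed within the scatter. A single step is thin evidence, but no change beyond the scatter is expected. The expected step is no change at the digits printed from compound 2 to compound 3 (within the scatter). For compound 3 the estimated value is 50500 nM, with an expected range of 25000 nM to 100000 nM.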

Compound 3, half-maximal effective concentration: 50500 nM
Estimate against measurement, compound 3: no gap at the digits printed; the range from low to high includes it.
By their numbers in this assay, from the lowest: compounds 1, 2 and 3 (each within the scatter of the next).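

Putting 4-methoxybenzyl on the aromatic nitrogen in place of 3,5-dichlorophenyl gives no change at the digits printed from compound 2 to compound 3 (within the scatter) in this assay and methoxy in place of fluoro on an aromatic carbon of the benzyl group gives no change at the digits printed from compound 1 to compound 3 (within the scatter) as well. This nitrogen has now carried three different groups, and the assay does not separate any of them. No measurement shown offers an explanation for this flat result. On these data alone, whether an amine or a carboxylic acid on the aromatic ring, or a longer chain joining that ring to the nitrogen, would move the value remains open. So does the effect of a change elsewhere on the shared core.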